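A Methyl on the Ester Chain, With Three Limits Behind

A few compounds are considered here, and "the series" means these few. Any claim that something is new, unique, unknown or untested is made for them only; others in the source may bear on it.

Three compounds were tested in a functional assay on SEM cells (Homo sapiens) for cytotoxicity, with a stated time of 72 h; on this read-out lower numbers stand for an effect already at smaller amounts and higher numbers for an effect only at larger amounts of compound. Compound 1 `C=C[C@@](C)(/C=C/c1ccc(O)c(/C=C/C(=O)OCC)c1)CCC=C(C)C` reached only the limit of the assay, > 36600 nM. Compound 2 `C=C[C@@](C)(/C=C/c1ccc(O)c(/C=C(\C)C(=O)OCC)c1)CCC=C(C)C` likewise gave only a limit, > 36600 nM. Compound 3 `CCOC(=O)/C=C/c1cc(/C=C/[C@](C)(/C=C/c2ccc(OC)cc2)CCC=C(C)C)ccc1O` differs in its core from compound 1 by 2-(4-methoxyphenyl)ethenyl in place of vinyl on a saturated chain carbon bound to a double-bonded chain carbon and two saturated chain carbons. In this assay compound 3 also gave only a limit, > 36600 nM.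

Because all three values sit at the same limit, the step that the two limits leave unreadable from compound 1 to compound 2 cannot be read, and the same holds for the step that the two limits leave unreadable from compound 1 to compound 3. What remains as evidence is the limit of > 36600 nM in this assay, at which 3 of the 3 values shown sit. The change from compound 1 to compound 2 is 2-(ethoxycarbonyl)prop-1-en-1-yl in place of 2-(ethoxycarbonyl)ethenyl on an aromatic carbon, and it is made a second time from compound 3 to compound 4 `CCOC(=O)/C(C)=C/c1cc(/C=C/[C@](C)(/C=C/c2ccc(OC)cc2)CCC=C(C)C)ccc1O`, which has not yet been measured; that change is 2-(ethoxycarbonyl)prop-1-en-1-yl in place of 2-(ethoxycarbonyl)ethenyl on an aromatic carbon, the same change at the same kind of place.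

Since the first occurrence of this change gave no readable step, there is no measured size to carry across. The expectation for compound 4 rests on the limit of > 36600 nM in this assay, at which 3 of the 3 values shown sit: where the whole series sits at the limit, compound 4 is expected to remain at or beyond it as well. The step that the limit leaves unreadable from compound 3 to compound 4 is therefore expected to be essentially flat. Compound 4 is estimated at 50000 nM in this assay, with an expected range from 20000 nM to 150000 nM, and most likely the assay will again report only a limit.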

Compound 4, half-maximal effective concentration: > 36600 nM
Compound 4: only a limit was reported; the forecaster's own chance of this, stated with the estimate: 85%; the middle value is on the limit's open side.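

Compound 4 gave only a limit in this assay, > 36600 nM. The steps from compound 3 to compound 4 and from compound 2 to compound 4 cannot be read, because both ends of each step are limits: the limit of > 36600 nM in this assay, at which 4 of the 4 values shown sit.

The compounds shown leave open how far beyond the limit each one lies, and whether either change moves the read-out at all.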